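Swapping methyl for chloro on a weakly active compound

A few compounds are considered here, and "the series" means these few. Any claim that something is new, unique, unknown or untested is made for them only; others in the source may bear on it.

In a functional assay on HCT-116 cells (Homo sapiens) for antiproliferative activity, read by MTT assay, with a stated time of 72 h (a higher number here means a weaker inhibitor, a lower number a stronger inhibitor), compound 1 `COc1ccc(N2C(=O)COc3ccc(-c4ccc(O)cc4)cc32)cc1` gives 26100 nM as a measured number. Compound 2 `Cc1ccc(N2C(=O)COc3ccc(-c4cnc5ccccc5c4)cc32)cc1` reads > 40000 nM in this assay and this is a limit of the assay, not a number. Compound 2 therefore stands at the limit of > 40000 nM in this assay, at which 1 of the 2 values shown sits, and has no exact position. Within the data shown here, compounds 1 and 2 differ in more than one place, so they offer no measured step to lean on.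

Compound 3 `O=C1COc2ccc(-c3cnc4ccccc4c3)cc2N1c1ccc(Cl)cc1` alters compound 2 in one place only chloro in place of methyl on an aromatic carbon with chloro in place of methyl on an aromatic carbon, turning 4-methylphenyl to 4-chlorophenyl. Among the measured compounds shown here, no measured pair shows this swap, so no step beyond the scatter is expected in this assay and the direction stays open. This expectation starts from compound 2 with its limit of > 40000 nM as the only anchor. The expected change is an at least 1.0-fold lower number from compound 2 to compound 3 (0.02 log units; that floor lies within the scatter) on this estimate. For compound 3 the estimated value is 38000 nM with an expected range from 14000 nM to 90000 nM and the assay may again report only a limit.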

Compound 3, half-maximal inhibitory concentration: 36100 nM
Estimate against measurement, compound 3: 1.1-fold (0.02 log units) above; low and high end bracket the measured number.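

Compound 2 reads > 40000 nM in this assay, and that is a limit of the assay, not a number. With 4-chlorophenyl in place of 4-methylphenyl, compound 3 gives 36100 nM, so this position on this core now carries an exact measured number, and the change from methyl to chloro can be stated as an at least 1.1-fold lower number from compound 2 to compound 3 (0.04 log units; that floor lies within the scatter). That figure is only a floor and not the full size of the step, because one end of the pair has no exact position: the limit of > 40000 nM in this assay, at which 1 of the 3 values shown sits.

Among these compounds, whether chloro and methyl truly differ at this place stays open, since a floor within the scatter cannot tell a real step from no step at all, and this single pair says nothing about how an amine or a carboxylic acid would read on the same phenyl ring. It also leaves open whether the same swap would give a similar result on the core of compound 1, which differs from compound 3 in more than one place and so cannot be compared with it directly.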